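This account rests on a few compounds, and the source may have more. Where it says the series, first, only, none or still open, it means among the compounds named here.

Three compounds share one core, a thiazole-like heterocycle joined to an amine-bearing aromatic ring and to a second aromatic ring, and all three have been tested in an assay on isolated protein for inhibition of Polyunsaturated fatty acid 5-lipoxygenase (Homo sapiens), read by HPLC, with stated times of 15 min and 10 min; on this read-out lower numbers stand for stronger inhibition and higher numbers for weaker inhibition. Compound 1, `COc1ccccc1Nc1nc(-c2ccc(Cl)cc2)cs1`, gives 2700 nM. Compound 2, `Oc1cccc(Nc2nc(-c3ccc(Cl)cc3)cs2)c1`, gives 1200 nM. Compound 3, `Oc1ccc(-c2csc(Nc3ccc(Cl)cc3)n2)cc1`, gives 500 nM. Compound 2 thus stands with the second highest of the three numbers: compound 1 shows a higher number, beyond the usual scatter, and compound 3 a lower one, again beyond the scatter.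

Compound 4, `Oc1cccc(Nc2nc(-c3ccccc3)cs2)c1`, has not yet been measured. Its change from compound 2 is hydrogen in place of chloro on an aromatic carbon, on a six-membered aromatic ring of carbon only, para to a large group. Going by the values given here, no two measured compounds differ by exactly this change, so the size of the step cannot be read from the data. The expectation is a modest rise in the number, of the order of a 2.1-fold higher number from compound 2 to compound 4 (0.32 log units; beyond the scatter), close to the edge of the scatter. Compound 4 is therefore expected to give about 2500 nM, within a range from 1000 nM to 6000 nM.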

Compound 4, half-maximal inhibitory concentration: 3700 nM
For compound 4 the middle estimate is 1.5-fold (0.17 log units) below the measured one; the measured number falls inside the stated range.
By their numbers in this assay, from the lowest: compound 3; then compound 2; then compounds 1 and 4 (each within the scatter of the next).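

Replacing the chloro with hydrogen on the carbon-only aromatic ring, para to a large group, gives in this assay a 3.1-fold higher number from compound 2 to compound 4 (0.49 log units; beyond the scatter). Going by these compounds alone, this is the first pair of compounds that differ only at this position, so the contribution of this one group can now be read directly. Here the compound with chloro gives stronger inhibition than the one with hydrogen, and the step lies beyond the usual scatter. No supporting measurement accounts for this step.

At this position, the compounds shown compare only chloro and hydrogen, so what a bromo, a methoxy or an amine would give there remains open. Also open, from the compounds shown here alone, is whether the same change would produce a step of similar size on other compounds.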